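The source may report more compounds than this note shows. Statements on the series, on what has been measured and on what is new or still open speak of the compounds shown alone.

Compound 1, `N#Cc1c(Nc2ccc(Cl)cc2)sc2ccccc12`: 45%
Compound 2, `COc1cc2sc(Nc3cccc(O)c3)c(C#N)c2cc1OC`: 11%

Going by the values given here, in a functional assay on HUVEC cells (Homo sapiens), read by fluorescence and microscopy, with a stated time of 6 h, tested at 10 uM (a lower number here means a stronger effect, a higher number a weaker effect of the compound at the concentration tested), compound 1 gives 45%, the highest of the two numbers measured so far; compound 2 stands a good deal lower and is the nearest point of comparison. Compound 3, `N#Cc1c(Nc2ccc(O)cc2)sc2ccccc12`, differs from compound 1 by hydroxy in place of chloro on an aromatic carbon. Among the compounds with values here, with no measured pair showing this exact change, only a small step in this assay is expected, tending downward and quite possibly within the usual scatter, as a number 9 percentage points lower from compound 1 to compound 3 (within the scatter). Compound 3 is therefore estimated at 36%, with a range from 15% to 58%.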

Compound 3, a percentage reported as activity, at one concentration (the size of the read-out at that concentration, not a potency): 25%
Beside the measured number, compound 3's estimate is 11 percentage points above it; the range from low to high includes it.
By their numbers in this assay, from the lowest: compound 2; then compound 3; then compound 1.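

Exchanging chloro for hydroxy on the aromatic carbon para to a large group gives a number 20 percentage points lower from compound 1 to compound 3 (beyond the scatter) in this assay. Going by these compounds alone, this is the first single-place comparison, and it shows that the read-out responds to the group at this position. Nothing measured here explains the step.

On these data alone, it remains open whether the step is specific to hydroxy or would also follow from other replacements of chloro at this place, such as a methoxy group or an amine. How a carboxylic acid would behave there is also unresolved.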